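The source may hold more compounds than are shown below. What is called first, only, known or untested is meant among the compounds shown, and "the series" means these compounds.

Among the measured compounds shown here, compound 3 `COc1ccc2occ(C(=O)Nc3ccccc3)c(=O)c2c1` stands second highest of the three numbers measured so far: in an assay on cells for inhibition of Amine oxidase [flavin-containing] B (Homo sapiens), read by fluorescence and Amplex Red, using microsomes, with a stated time of 15 min (a lower number here means a stronger inhibitor, a higher number a weaker inhibitor), compound 3 gives 41.8 nM. Its nearest neighbour is compound 1 `Cc1ccc2occ(C(=O)Nc3ccccc3)c(=O)c2c1`, which in this assay gives 21.4 nM; the step of a 2.0-fold higher number from compound 1 to compound 3 (0.29 log units; within the scatter) lies within the scatter. Furthest from it is compound 2 `Cc1ccc2occ(C(=O)Nc3ccc(O)cc3)c(=O)c2c1`, which in this assay gives 513 nM; the step of a 24-fold higher number from compound 1 to compound 2 (1.38 log units; beyond the scatter) is a large one.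

Compound 4 `COc1ccc2occ(C(=O)Nc3ccc(C)cc3)c(=O)c2c1` differs from compound 3 by methyl in place of hydrogen on an aromatic carbon. For the measured compounds named here, two measured steps bear on this. The step of a 2.0-fold higher number from compound 1 to compound 3 (0.29 log units; within the scatter) exchanges methyl for methoxy on the core and hardly moves the number, so those two groups do not separate the compounds here. Going by the values given here, the step of a 24-fold higher number from compound 1 to compound 2 (1.38 log units; beyond the scatter) puts a hydroxy group in place of an aromatic hydrogen and weakens inhibition sharply; it shows that a group entering in place of an aromatic hydrogen can cost a great deal, though hydroxy and methyl are different groups and no methyl-for-hydrogen step has been measured. Compound 4 is therefore expected to show a 1.4-fold higher number from compound 3 to compound 4 (0.16 log units; within the scatter), a modest weakening that may not exceed the scatter. The estimate for compound 4 is 60 nM, within a range from 20 nM to 200 nM.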

Compound 4, half-maximal inhibitory concentration: 211 nM
Estimate against measurement, compound 4: 3.5-fold (0.55 log units) below; measured number above the stated range.
By their numbers in this assay, from the lowest: compounds 1 and 3 (each within the scatter of the next); then compound 4; then compound 2.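

In this assay, among the compounds shown here, the step of a 5.0-fold higher number from compound 3 to compound 4 (0.70 log units; beyond the scatter) is the first measured case of methyl in place of hydrogen, and it lies beyond the scatter: going from phenyl to 4-methylphenyl, a change of one carbon on an aromatic carbon para to a large group, is not neutral here. Read with the step of a 24-fold higher number from compound 1 to compound 2 (1.38 log units; beyond the scatter), it shows that a higher number on this phenyl ring is not confined to hydroxy, since two different groups on that ring have now each given a higher number, although one sits on the methyl-bearing core and the other on the methoxy-bearing core. Nothing available on these compounds explains why this single carbon raises the number.

The compounds shown leave open how the methyl and hydroxy groups compare on one and the same core, as the two steps differ in the core as well as in the entering group. They also leave open whether other groups at this place, such as an amine, a chlorine atom or a longer chain, would raise the number as well.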